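Charged ring in place of pyridin-3-yl in the chalcone series

This account rests on a few compounds, and the source may have more. Where it says the series, first, only, none or still open, it means among the compounds named here.

Among the measured compounds shown here, in a functional assay with Rattus norvegicus as the target (on this read-out lower numbers stand for stronger inhibition and higher numbers for weaker inhibition), compound 2 `COc1cc(C(=O)/C=C/c2cccnc2)cc(OC)c1OC` gives 30000 nM, the highest of the two numbers so far; compound 1 `COc1cc(C(=O)/C=C/c2ccncc2)cc(OC)c1OC` gives 7000 nM. For the measured compounds named here, the one measured step, a 4.3-fold higher number from compound 1 to compound 2 (0.63 log units; beyond the scatter), exchanged pyridin-4-yl for pyridin-3-yl. Compound 3 `COc1cc(C(=O)/C=C/c2cc[n+](C)cc2)cc(OC)c1OC` differs from compound 2 in that (a group of 7 heavy atoms (6 carbon, 1 nitrogen; one six-membered aromatic ring with 1 hetero atom) in place of a group of 6 heavy atoms (5 carbon, 1 nitrogen; one six-membered aromatic ring with 1 hetero atom), on a double-bonded chain carbon bound to a double-bonded chain carbon). Going by the values given here, the entering group carries a net charge, which no measured compound does, so no step bears directly on it; the step from compound 1 to compound 2 is the only guide. Compound 3 is expected near 9000 nM, within 2000 nM to 40000 nM. This means an expected 3.3-fold lower number from compound 2 to compound 3 (0.52 log units; beyond the scatter).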

Compound 3, half-maximal inhibitory concentration: > 50000 nM
Compound 3: no number, only a limit; the forecaster's own chance of this, stated with the estimate: 10%; at least 5.5-fold (0.74 log units) between middle value and limit.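

The reading for compound 3 in this assay is a limit and not a number: the limit of > 50000 nM in this assay, at which 1 of the 3 values shown sits. Even so, this place tolerates the net charge of +1 poorly relative to pyridin-4-yl, with an at least 7.1-fold higher number from compound 1 to compound 3 (0.85 log units; beyond the scatter). Against pyridin-3-yl the step is an at least 1.6-fold higher number from compound 2 to compound 3 (0.22 log units; that floor lies within the scatter), so no order between those two compounds can be claimed.

Going by these compounds, how far the true value of compound 3 lies past the limit stays open. Also open, on these data alone, is whether a primary amine or a carboxylic acid at this place would give a number that can be read.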